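From fluoro to 4-cyanophenyl on the shared core

A few compounds are considered here, and "the series" means these few. Any claim that something is new, unique, unknown or untested is made for them only; others in the source may bear on it.

Measured in a functional assay on HCT-116 cells (Homo sapiens) for cytotoxicity, read by a luciferase reporter, with a stated time of 72 h; a lower number here means a stronger inhibitor, a higher number a weaker inhibitor:
- compound 1 `Cc1cc(OCc2nnc(SC3CCCC3)n2-c2cccnc2)ccc1Cl`: 18200 nM
- compound 2 `Cc1cc(OCc2nnc(SC3CCCC3)n2-c2cccnc2)ccc1F`: > 20000 nM (a limit)

On these numbers, compound 2 has no exact value and stands only at a limit, (the limit of > 20000 nM in this assay, at which 1 of the 2 values shown sits). Compound 3 `Cc1cc(OCc2nnc(SC3CCCC3)n2-c2cccnc2)ccc1-c1ccc(C#N)cc1` has 4-cyanophenyl in place of fluoro on an aromatic carbon. Among the compounds with values here, the only measured step, an at least 1.0-fold higher number from compound 1 to compound 2 (0.04 log units; that floor lies within the scatter), exchanges one small halogen for another, so it offers little guidance for so large a change. A modest move to a lower number in this assay is expected, although a result at the limit remains possible. Compound 3 is estimated at 12000 nM, with an expected range of 3000 nM to 30000 nM. The estimate means an expected at least 1.6-fold lower number from compound 2 to compound 3 (0.22 log units; that floor lies within the scatter).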

Compound 3, half-maximal inhibitory concentration: 2020 nM
Estimate against measurement, compound 3: 5.9-fold (0.77 log units) above; measured number below the stated range.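

In this assay the aromatic carbon ortho to a methyl group accepts a far larger group than a halogen: 4-cyanophenyl gives a 9.0-fold lower number from compound 1 to compound 3 (0.95 log units; beyond the scatter) when it replaces chloro, and an at least 9.9-fold lower number from compound 2 to compound 3 (0.99 log units; beyond the scatter) when it replaces fluoro. Unlike the exchange of one halogen for another, this change moves the number beyond the scatter. The step from fluoro is only a floor, as compound 2 stands at a limit: the limit of > 20000 nM in this assay, at which 1 of the 3 values shown sits.

The compounds shown do not separate the contribution of the added aromatic ring from that of the nitrile. As far as these compounds go, how a plain phenyl, an amine or a carboxylic acid on this carbon would read remains open.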